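From isobutyl to cyclohexyl on a shared core

The source may hold more compounds than are shown below. What is called first, only, known or untested is meant among the compounds shown, and "the series" means these compounds.

Measured so far in an ADME assay on Huh-7 cells (Homo sapiens) for cytotoxicity, with a stated time of 72 h; on this read-out lower numbers stand for higher toxicity in this test and higher numbers for lower toxicity in this test:
Compound 1 `CCOc1cccc2c1S(=O)(=O)N=C2C1=C(O)[C@H](C(C)C)N(CCC(C)(C)C)C1=O`: > 33000 nM
Compound 2 `CCOc1cccc2c1S(=O)(=O)N=C2C1=C(O)[C@H](CC(C)C)N(CCC(C)(C)C)C1=O`: > 33000 nM

Compound 2 has no exact number and stands only at a limit of this assay, > 33000 nM. Both measured compounds share this position: the limit of > 33000 nM in this assay, at which 2 of the 2 values shown sit.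

The next compound, compound 3 `CCOc1cccc2c1S(=O)(=O)N=C2C1=C(O)[C@H](C2CCCCC2)N(CCC(C)(C)C)C1=O`, has the same core but carries cyclohexyl in place of isobutyl on a saturated ring carbon. Among the compounds with values here, one measured step bears on this change, as it also swaps the group on that carbon: a step that the two limits leave unreadable from compound 1 to compound 2. With no size to carry over from that step, no change beyond the usual scatter is expected in this assay, and no direction can be given. Another limit is the likeliest result. The estimate for compound 3 is 33000 nM, with an expected range of 15000 nM to 40000 nM. The expected step is a number no higher from compound 2 to compound 3 (the limit leaves the size open).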

Compound 3, half-maximal cytotoxic concentration: > 33000 nM
Compound 3 ended at the assay's limit; the forecaster's own chance of this, stated with the estimate: 75%; the middle value lies on the limit itself.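

The steps among compound 1, compound 2 and compound 3 cannot be read, since all three values are limits and not numbers: the limit of > 33000 nM in this assay, at which 3 of the 3 values shown sit.

The compounds shown leave open how changing the group on that saturated ring carbon would shift an exact value in this assay.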